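The source may report more compounds than this note shows. Statements on the series, on what has been measured and on what is new or still open speak of the compounds shown alone.

Compound 1 `COc1cc(/C=C/C(=O)c2cccc(-n3cc(-c4ccc(Cl)cc4)[nH]c3=O)c2)ccc1O`: in a functional assay on EKVX cells (Homo sapiens) for inhibition (on this read-out lower numbers stand for stronger inhibition of growth and higher numbers for weaker inhibition of growth), compound 1 gives 9610 nM
Compound 2 `COc1cc(/C=C/C(=O)c2cccc(-n3cc(-c4ccccc4)[nH]c3=O)c2)cc(OC)c1OC`: compound 2 gives 2300 nM
Compound 3 `COc1ccc(-c2cn(-c3cccc(C(=O)/C=C/c4ccc(O)c(OC)c4)c3)c(=O)[nH]2)cc1`: compound 3 gives 13400 nM

Among these three, compound 2 stands at the lowest number in this assay. The gap from compound 2 to compound 1 and the gap from compound 2 to compound 3 both lie beyond the scatter, so compound 2 is the strongest inhibitor of growth in this small set.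

Compound 4 `COc1cc(/C=C/C(=O)c2cccc(-n3cc(-c4ccc(Cl)cc4)[nH]c3=O)c2)cc(OC)c1OC` has not yet been measured. It differs from compound 2 in one place: chloro in place of hydrogen on an aromatic carbon.

Going by the values given here, no measured pair shows exactly this hydrogen-to-chloro exchange on the shared core. Among the compounds with values here, the only step that bears on it is the one between compound 1 and compound 3, a 1.4-fold higher number from compound 1 to compound 3 (0.14 log units; within the scatter), which swaps chloro for methoxy on the same aromatic carbon and leaves the number within the scatter. That step suggests the substituent on this ring carries little weight in this assay, though it does not test the bare ring.

Compound 4 is therefore expected to sit close to compound 2, with a step of about no change at the digits printed from compound 2 to compound 4 (within the scatter), and no change beyond the scatter is anticipated. The estimate for compound 4 is 2300 nM, with a range from 1000 nM to 5500 nM.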

Compound 4, concentration for 50% growth inhibition: "not active" (no number reported)
Compound 4 has no reported number here; no gap can be computed for the estimate.
By their numbers in this assay, from the lowest: compound 2; then compounds 1 and 3 (each within the scatter of the next).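

In this assay, going by these compounds alone, compound 4 is reported as "not active" with no number, so no step from compound 2 to compound 4 can be read. Nothing available here accounts for this result. The compounds shown leave open how large the effect of the phenyl to 4-chlorophenyl exchange is on this shared core.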